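The source may report more compounds than this note shows. Statements on the series, on what has been measured and on what is new or still open speak of the compounds shown alone.

In an assay on CHO cells for displacement of a labelled ligand from adenosine receptor A3 (Homo sapiens), read by scintillation counting, with a stated time of 120 min, tested at 10 uM (on this read-out lower numbers stand for less inhibition and higher numbers for more inhibition at the one concentration tested (going by the name of the read-out)), three analogues of a shared core were examined. Compound 1 (`Nc1scc(CN2CCN(c3ccccc3C(F)(F)F)CC2)c1C(=O)c1ccc(Cl)cc1`) gives 0% when tested. Compound 2 (`Nc1scc(CN2CCN(c3c(F)cccc3F)CC2)c1C(=O)c1ccc(Cl)cc1`) gives 4% in the same assay. Compound 3 (`Nc1scc(CN2CCN(c3c(F)cc(F)cc3F)CC2)c1C(=O)c1ccc(Cl)cc1`) gives 0% under the same conditions. On these numbers compound 3 stands level with compound 1 at the digits shown and within the scatter of compound 2: the step of no change at the digits printed from compound 1 to compound 3 (within the scatter) and the step of a number 4 percentage points lower from compound 2 to compound 3 (within the scatter) are both within the scatter, as is a number 4 percentage points higher from compound 1 to compound 2 (within the scatter) between the other two.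

Compound 4 (`Nc1scc(CN2CCN(c3ccccc3Cl)CC2)c1C(=O)c1ccc(Cl)cc1`) differs from compound 3 in one place: 2-chlorophenyl in place of 2,4,6-trifluorophenyl on an amine nitrogen in a ring. Within the data shown here, the steps that bear on this change are the three among compounds 1, 2 and 3, where three different aryl groups on the amine nitrogen in a ring left the read-out unchanged within its scatter. A step beyond the scatter is therefore not expected in either direction. The expected step is a number 2 percentage points higher from compound 3 to compound 4 (within the scatter) on that basis. Compound 4 is accordingly estimated at 2% with a range from -6% to 12%.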

Compound 4, a percentage reported as inhibition, at one concentration (the size of the read-out at that concentration, not a potency): 0%
Compound 4: middle estimate off by 2 percentage points, on the high side; low and high end bracket the measured number.
By their numbers in this assay, from the lowest: compounds 1, 3, 4 and 2 (each within the scatter of the next).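

In this assay the result adds a chlorine-bearing aryl group on the amine nitrogen in a ring to the fluorine-bearing ones: the exchange for 2,4,6-trifluorophenyl gives no change at the digits printed from compound 3 to compound 4 (within the scatter), and the exchange for 2,6-difluorophenyl gives a number 4 percentage points lower from compound 2 to compound 4 (within the scatter). The exchange of a single substituent, chloro in place of trifluoromethyl on an aromatic carbon, gives no change at the digits printed from compound 1 to compound 4 (within the scatter), so these two groups cannot be told apart on this aryl ring. All four aryl groups now lie within the scatter of one another, and no measurement at hand offers an explanation for this.

From the compounds shown here alone, it remains open whether a methoxy group, a hydroxyl group or an amine on this aryl ring would move the read-out beyond the scatter. Equally open, going by these compounds, is whether replacing the aryl group with a longer alkyl chain would do so.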